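A Methyl Step Repeated on a Second Core

The source may hold more compounds than are shown below. What is called first, only, known or untested is meant among the compounds shown, and "the series" means these compounds.

Measured so far:
Compound 1, `COc1cc2c(Oc3ccc(NC(=O)c4cc(-c5ccccc5)ccn4)cc3F)ccnc2cc1OCCCN1CCCC1`, gives 130 nM in a functional assay on NCI-H460 cells (Homo sapiens) for cytotoxicity, read by MTT assay, with a stated time of 72 h; a lower number here means a stronger inhibitor, a higher number a weaker inhibitor.
Compound 2, `COc1cc2c(Oc3ccc(NC(=O)c4cc(-c5ccc(C)cc5)ccn4)cc3F)ccnc2cc1OCCCN1CCCC1`, gives 160 nM.
Compound 3, `COc1cc2c(Oc3ccc(NC(=O)c4cc(-c5ccccc5)ccn4)cc3F)ccnc2cc1OCCCN1CCCCC1`, gives 120 nM.

Compound 2 differs from compound 1 by methyl in place of hydrogen on an aromatic carbon. That change produced a 1.2-fold higher number from compound 1 to compound 2 (0.09 log units; within the scatter), so the two compounds cannot be told apart by this measurement. Compound 3 carries a different core than compound 1, the difference being (piperidin-1-yl in place of pyrrolidin-1-yl on a saturated chain carbon, three bonds along the chain from an oxygen on an aromatic ring); the two cores gave a 1.1-fold lower number from compound 1 to compound 3 (0.03 log units; within the scatter), again within the scatter.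

Compound 4, `COc1cc2c(Oc3ccc(NC(=O)c4cc(-c5ccc(C)cc5)ccn4)cc3F)ccnc2cc1OCCCN1CCCCC1`, has not yet been measured. It differs from compound 3 by methyl in place of hydrogen on an aromatic carbon. The place of the change is described in the same words as for the step from compound 1 to compound 2, so this is the same change, now made on the core of compound 3. Since both earlier steps stayed within the scatter, the step from compound 3 to compound 4 is expected to be small as well, roughly a 1.2-fold higher number from compound 3 to compound 4 (0.08 log units; within the scatter), because a 1.2-fold higher number from compound 1 to compound 2 (0.09 log units; within the scatter). Compound 4 is therefore estimated to give 145 nM, expected between 70 nM and 300 nM.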

Compound 4, half-maximal inhibitory concentration: 160 nM
Compound 4: the middle estimate sits 1.1-fold (0.04 log units) below what was measured; measured number inside the range.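

In this assay, the methyl change on the core of compound 3 gives (a 1.3-fold higher number from compound 3 to compound 4 (0.12 log units; within the scatter)), and the change from pyrrolidin-1-yl to piperidin-1-yl with the methyl already present gives (no change at the digits printed from compound 2 to compound 4 (within the scatter)). The methyl step therefore reads the same on both cores: the same change on two cores in this assay, a 1.2-fold higher number (0.09 log units; within the scatter) from compound 1 to compound 2 and a 1.3-fold higher number (0.12 log units; within the scatter) from compound 3 to compound 4, 1.1-fold (0.03 log units) apart, within the scatter of two such steps. Within the data shown here, the ring change also reads the same with and without the methyl, yet every step here lies within the scatter, so these four compounds show only that neither change moved the number measurably, and not that either change would behave this way on any further core: the same change on two cores in this assay, a 1.1-fold lower number (0.03 log units; within the scatter) from compound 1 to compound 3 and no change at the digits printed (within the scatter) from compound 2 to compound 4, 1.1-fold (0.03 log units) apart, within the scatter of two such steps.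

Going by these compounds, it remains open whether a methoxy group, a chlorine or a carboxylic acid in place of the methyl, at the same place on the aromatic ring, would move the number beyond the scatter. Also open, on these data alone, is what a dimethylamino group in place of the saturated ring, or a longer chain leading to that ring, would do.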